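This account rests on a few compounds, and the source may have more. Where it says the series, first, only, none or still open, it means among the compounds named here.

Measured so far in a functional assay on NCI-H460 cells (Homo sapiens) for cytotoxicity, read by MTT assay, with a stated time of 72 h; on this read-out lower numbers stand for stronger inhibition and higher numbers for weaker inhibition:
compound 1, `COc1ccc(/N=C2\C=C(OCc3cn(S(=O)(=O)c4ccc(C)cc4)nn3)C(=O)c3ccccc32)cc1`: 8390 nM
compound 2, `Cc1ccc(S(=O)(=O)n2cc(COC3=C/C(=N\c4ccc(F)cc4)c4ccccc4C3=O)nn2)cc1`: 7360 nM

Among the measured compounds shown here, compound 2 stands beside compound 1 with a number that the scatter does not separate from it: the single measured step is a 1.1-fold lower number from compound 1 to compound 2 (0.06 log units; within the scatter). On the numbers shown, the two compounds are indistinguishable in this assay.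

Compound 3 is `Cc1ccc(S(=O)(=O)n2cc(COC3=C/C(=N\c4ccccc4)c4ccccc4C3=O)nn2)cc1`. It differs from compound 2 as follows: hydrogen in place of fluoro on an aromatic carbon.

For the measured compounds named here, only one measured step bears on this, and only loosely, since it exchanges one group for another at the same place rather than removing the group altogether. That step, a 1.1-fold lower number from compound 1 to compound 2 (0.06 log units; within the scatter), was within the scatter. Nothing in the two measured compounds indicates that this place on the aromatic ring governs the read-out, so the working expectation is that removing the fluoro will also leave the number essentially where it is.

Accordingly the step from compound 2 to compound 3 is estimated as a 1.0-fold higher number from compound 2 to compound 3 (0.01 log units; within the scatter), within the scatter. Compound 3 is therefore expected to give about 7500 nM in this assay. For compound 3 the expected range runs from 4000 nM to 14000 nM.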

Compound 3, half-maximal inhibitory concentration: 7220 nM
Beside the measured number, compound 3's estimate is 1.0-fold (0.02 log units) above it, within the range that was stated.
By their numbers in this assay, from the lowest: compounds 3, 2 and 1 (each within the scatter of the next).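

In this assay, the unsubstituted phenyl compound provides the reference that the earlier pair lacked: the change from 4-fluorophenyl to phenyl gives a 1.0-fold lower number from compound 2 to compound 3 (0.01 log units; within the scatter), and hydrogen in place of methoxy gives a 1.2-fold lower number from compound 1 to compound 3 (0.07 log units; within the scatter). At this place on the aromatic ring, para to a large group, removing the substituent therefore does no more to separate the numbers than exchanging fluoro for methoxy did, and neither group can be told apart from hydrogen on this read-out. No supporting data accompany these results that could explain this flat response.

Going by these compounds, whether a substituent of another kind at this place, such as an amine, a carboxylic acid or a longer chain, would move the number beyond the scatter remains open. The three compounds also differ only at this one place, so they leave open how much the other parts of the shared core contribute to the activity in this assay.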